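Fluorine on a Second Ring: Acids Against a Prostaglandin Receptor

The source may report more compounds than this note shows. Statements on the series, on what has been measured and on what is new or still open speak of the compounds shown alone.

Measured so far:
compound 1 `O=C(O)Cc1sc(C(c2ccccc2)c2ccccc2)nc1-c1ccccc1`: 570 nM
compound 2 `O=C(O)Cc1sc(C(c2ccccc2)c2ccccc2)nc1-c1ccc(F)cc1`: 8.7 nM
compound 3 `O=C(O)Cc1sc(C(c2ccc(F)cc2)c2ccc(F)cc2)nc1-c1ccncc1`: 5.3 nM

These values come from an in vitro assay on HEK385-7 cells for displacement of a labelled ligand from prostaglandin D2 receptor 2 (Homo sapiens); on this read-out higher numbers stand for weaker inhibition and lower numbers for stronger inhibition. Compound 1 and compound 2 differ by fluoro in place of hydrogen on an aromatic carbon; this gave a 66-fold lower number from compound 1 to compound 2 (1.82 log units; beyond the scatter). Compound 3 has another core; the difference between its core and that of compound 1 is not broken down here. Compound 4 `O=C(O)Cc1sc(C(c2ccc(F)cc2)c2ccc(F)cc2)nc1-c1ccnc(F)c1` is not yet measured. It differs from compound 3 by fluoro in place of hydrogen on an aromatic carbon. This is the same kind of change as that from compound 1 to compound 2, but the place differs: there the fluoro entered a six-membered aromatic ring of carbon only, para to a large group; here it enters a six-membered aromatic ring with one nitrogen, next to the ring nitrogen and meta to a large group. Given that the place differs, and because compound 3 already stands at 5.3 nM, a much smaller step than a 66-fold lower number from compound 1 to compound 2 (1.82 log units; beyond the scatter) is expected: a 1.1-fold lower number from compound 3 to compound 4 (0.03 log units; within the scatter). For compound 4 the estimate in this assay is 5 nM, with a likely range from 1.5 nM to 15 nM.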

Compound 4, half-maximal inhibitory concentration: 0.48 nM
Beside the measured number, compound 4's estimate is 10-fold (1.02 log units) above it; the whole stated range lies above it.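

In this assay, the same swap of hydrogen for fluoro again gave stronger inhibition, with an 11-fold lower number from compound 3 to compound 4 (1.04 log units; beyond the scatter), so the direction of the change held on both cores. The size of the step did not carry over: the same change on two cores in this assay, a 66-fold lower number (1.82 log units; beyond the scatter) from compound 1 to compound 2 and an 11-fold lower number (1.04 log units; beyond the scatter) from compound 3 to compound 4, 5.9-fold (0.77 log units) apart, beyond the scatter of two such steps. Among the compounds shown here, with only two pairs, this shows that the direction was shared here, not that it would hold on a further core, and because the fluoro also entered a different ring in each pair, the effect of the core cannot be separated from that of the place.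

On these data alone, it remains open whether chloro or methyl in place of the fluoro in the 2-fluoropyridin-4-yl group would give a similar step.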